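Cyclobutyl to methoxymethyl on the shared core

The compounds below may be only part of what the source reports. "The series", "measured", "known", "first", "only" and "open" are said of these compounds alone.

Compound 1 `CN1CCn2nc(CNC(=O)[C@@H](N)CCSC[C@H]3O[C@@H](n4cnc5c(N)ncnc54)[C@H](O)[C@@H]3O)cc2C1` gives 50000 nM in an assay on Sf9 cells for inhibition of histone-lysine N-methyltransferase EZH2 (Homo sapiens), read by scintillation counting, in the presence of a further agent that is not named here; a higher number here means a weaker inhibitor, a lower number a stronger inhibitor. Going by the values given here, compound 2 `Nc1ncnc2c1ncn2[C@@H]1O[C@H](CSCC[C@H](N)C(=O)NCc2cc(C3CCC3)[nH]n2)[C@@H](O)[C@H]1O` gives 3000 nM, and the single measured step, a 17-fold lower number from compound 1 to compound 2 (1.22 log units; beyond the scatter), shows that the group on the saturated chain carbon bound to the amide-type nitrogen carries much of the potency. On the two numbers available, compound 2 stands with the lowest number, its nearest neighbour being compound 1.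

Compound 3 `COCc1cc(CNC(=O)[C@@H](N)CCSC[C@H]2O[C@@H](n3cnc4c(N)ncnc43)[C@H](O)[C@@H]2O)n[nH]1` differs from compound 2 in one place: methoxymethyl in place of cyclobutyl on an aromatic carbon. Among the compounds with values here, no measured step exchanges one substituent for another on this five-membered aromatic ring; the only step that bears on the region, the one from compound 1 to compound 2, replaced the whole group and was large. The present change is smaller, so a step of moderate size toward a higher number is expected, a 2.3-fold higher number from compound 2 to compound 3 (0.37 log units; beyond the scatter). Compound 3 is therefore estimated at 7000 nM, within 2000 nM to 25000 nM.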

Compound 3, half-maximal inhibitory concentration: 40000 nM
Compound 3: the middle estimate sits 5.7-fold (0.76 log units) below what was measured; measured number above the stated range.
By their numbers in this assay, from the lowest: compound 2; then compounds 3 and 1 (each within the scatter of the next).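

In this assay, methoxymethyl in place of cyclobutyl on the aromatic carbon gives a 13-fold higher number from compound 2 to compound 3 (1.12 log units; beyond the scatter) with the rest of compound 2 unchanged, so this one substituent is enough for a large step. Going by these compounds alone, the comparison with the earlier compound, a 1.3-fold lower number from compound 1 to compound 3 (0.10 log units; within the scatter) and thus within the scatter, shows that among the three compounds only the one with cyclobutyl stands apart, and compound 3 and compound 1 cannot be told apart. No evidence on the cause of this step is at hand.

The compounds shown leave open whether the four-membered ring of cyclobutyl or the oxygen of methoxymethyl accounts for the step. As far as these compounds go, how isopropyl, cyclopentyl or phenyl on this aromatic carbon would read also remains open.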